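The source may hold more compounds than are shown below. What is called first, only, known or untested is meant among the compounds shown, and "the series" means these compounds.

Compound 2 `CCC(NC(=O)C(CC(C)C)NC(=O)OCc1ccccc1)C(=O)C(=O)NCc1ccc2ccccc2n1` carries the shared core of the series with a quinolin-2-yl group on a saturated chain carbon bound to an amide-type nitrogen. Going by the values given here, in an assay on isolated protein (Oryctolagus cuniculus) for inhibition of Calpain-2 catalytic subunit (Homo sapiens) (a lower number here means a stronger inhibitor, a higher number a weaker inhibitor), compound 2 gives 600 nM, the highest of the two numbers so far, while its nearest neighbour, compound 1 `CCC(NC(=O)C(CC(C)C)NC(=O)OCc1ccccc1)C(=O)C(=O)NCc1ccccc1`, gives 350 nM in this assay; the step of a 1.7-fold higher number from compound 1 to compound 2 (0.23 log units; within the scatter) lies within the scatter, so the two cannot be ordered.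

Compound 3 `CCC(NC(=O)C(CC(C)C)NC(=O)OCc1ccccc1)C(=O)C(=O)NCc1nccc2ccccc12` has the same atoms as compound 2, joined differently: isoquinolin-1-yl in place of quinolin-2-yl on a saturated chain carbon bound to an amide-type nitrogen. Among the compounds with values here, the only measured step that bears on this position is a 1.7-fold higher number from compound 1 to compound 2 (0.23 log units; within the scatter), which replaced phenyl by quinolin-2-yl and stayed within the scatter. Nothing measured separates the two arrangements of the same ring system, so no step beyond the scatter is expected in this assay from compound 2 to compound 3, and the estimate is written as no change at the digits printed from compound 2 to compound 3 (within the scatter). Compound 3 is therefore expected to give about 600 nM in this assay, with a plausible range from 250 nM to 1500 nM.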

Compound 3, inhibition constant: 150 nM
For compound 3 the middle estimate is 4.0-fold (0.60 log units) above the measured one; measured number outside the range, below it.
By their numbers in this assay, from the lowest: compound 3; then compounds 1 and 2 (each within the scatter of the next).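

In this assay the position on a saturated chain carbon bound to an amide-type nitrogen proved sensitive to how the same ring atoms are joined: the change gives a 4.0-fold lower number from compound 2 to compound 3 (0.60 log units; beyond the scatter) even though quinolin-2-yl and isoquinolin-1-yl have identical counts of heavy atoms, rings and hydrogen-bond acceptors. Isoquinolin-1-yl also separates from phenyl, with a 2.3-fold lower number from compound 1 to compound 3 (0.37 log units; beyond the scatter) for that replacement, which makes compound 3 the strongest inhibitor of the three, whereas the earlier pair, phenyl and quinolin-2-yl, could not be ordered. No supporting measurement is available to explain why the two arrangements of the same atoms differ.

The compounds shown leave open whether the lower number depends on the ring nitrogen or on the two-ring group as a whole, a question that naphthalen-1-yl, with carbon-only rings, and pyridin-2-yl, with a single ring, would help to settle. They also leave open whether isoquinolin-1-yl would keep its advantage over quinolin-2-yl if the ethyl chain of the shared core were replaced by a longer chain.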